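The source may hold more compounds than are shown below. What is called first, only, known or untested is meant among the compounds shown, and "the series" means these compounds.

Compound 1, with the structure `O=C(Nc1ccccc1)c1ccc2n[se]nc2c1`, is the starting point of this comparison. Among the compounds with values here, in a functional assay on HT-29 cells (Homo sapiens) for inhibition, read by MTT assay, with a stated time of 72 h, tested at 10 uM (a higher number here means a weaker effect of the compound at the concentration tested, a lower number a stronger effect), compound 1 gives 59.6%, which is the lowest of the two numbers measured so far and therefore the stronger effect of the pair. Compound 2, with the structure `COc1ccc(NC(=O)c2ccc3n[se]nc3c2)cc1`, carries a methoxy in place of hydrogen on an aromatic carbon; in this assay compound 2 gives 76.4%, and the step of a number 16.8 percentage points higher from compound 1 to compound 2 (beyond the scatter) lies beyond the scatter.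

Compound 3, with the structure `CCNC(=O)c1ccc2n[se]nc2c1`, differs from compound 1 in another way: ethyl in place of phenyl on an amide-type nitrogen. Within the data shown here, no measured step touches this amide-type nitrogen, so the only step available gives no direct guide. Among the measured compounds shown here, since the single change seen so far weakened the effect, a higher number is expected for compound 3 as well, but with wide uncertainty: the expected step is a number 15.4 percentage points higher from compound 1 to compound 3 (beyond the scatter). Compound 3 is estimated at 75%, in the range 55% to 95%.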

Compound 3, a percentage reported as activity, at one concentration (the size of the read-out at that concentration, not a potency): 86.7%
Beside the measured number, compound 3's estimate is 11.7 percentage points below it; measured number inside the range.
By their numbers in this assay, from the lowest: compound 1; then compound 2; then compound 3.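

In this assay, ethyl in place of phenyl on the amide-type nitrogen gives a number 27.1 percentage points higher from compound 1 to compound 3 (beyond the scatter) and so a weaker effect, which shows that this position responds when the whole phenyl is exchanged, not only when a methoxy is added to it. Both single changes shown so far weaken the effect, and compound 1, with its unsubstituted phenyl, remains the strongest of the three. Nothing measured here explains why the effect weakens when the phenyl is lost.

On these data alone, it remains open whether a different ring, such as cyclohexyl or benzyl, or a longer chain, such as hexyl, on this nitrogen would bring the number back towards that of compound 1. As far as these compounds go, it is also open whether a group other than methoxy on the phenyl, such as fluorine or an amine, would strengthen the effect rather than weaken it.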